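This account rests on a few compounds, and the source may have more. Where it says the series, first, only, none or still open, it means among the compounds named here.

Compound 3 `N#Cc1ccc2[nH]c(-c3ccc4[nH]c(-c5ccc6[nH]cnc6c5)nc4c3)nc2c1` gives in a functional assay on RPMI 8402 cells (Homo sapiens) for cytotoxicity (on this read-out lower numbers stand for stronger inhibition and higher numbers for weaker inhibition), only a limit of the assay, > 25000 nM. Compound 1 `N#Cc1ccc2[nH]c(-c3ccc4[nH]cnc4c3)nc2c1` likewise gives only a limit in this assay, > 25000 nM. Compound 2 `CCCc1ccc2[nH]c(-c3ccc4[nH]c(-c5ccc6[nH]cnc6c5)nc4c3)nc2c1` gives 7600 nM in this assay. The two measured steps are a step that the two limits leave unreadable from compound 1 to compound 3 and an at least 3.2-fold higher number from compound 2 to compound 3 (0.51 log units; beyond the scatter). Evidence is the limit of > 25000 nM in this assay, at which 2 of the 3 values shown sit, so the step to compound 4 starts from a limit. Compound 4 `c1cc(-c2ccc3[nH]c(-c4ccc5[nH]c(-c6ccc7[nH]cnc7c6)nc5c4)nc3c2)ccn1` differs from compound 3 by pyridin-4-yl in place of cyano on an aromatic carbon. The step from compound 2 to compound 3 is the one that bears on it: removing cyano on that aromatic carbon gave an at least modest improvement there. Compound 4 is therefore expected to give a measurable number, estimated at 10000 nM with a range of 3000 nM to 30000 nM. For compound 4 this estimate means an expected step of an at least 2.5-fold lower number from compound 3 to compound 4 (0.39 log units; beyond the scatter).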

Compound 4, half-maximal inhibitory concentration: 35 nM
Beside the measured number, compound 4's estimate is 290-fold (2.46 log units) above it; the whole stated range lies above it.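

In this assay, among the compounds shown here, this aromatic carbon proves far more responsive than the earlier compounds showed: pyridin-4-yl in place of cyano gives an at least 710-fold lower number from compound 3 to compound 4 (2.85 log units; beyond the scatter), and pyridin-4-yl in place of propyl gives a 220-fold lower number from compound 2 to compound 4 (2.34 log units; beyond the scatter). The cyano and propyl pair had shown only an at least modest span here, whereas a six-membered aromatic ring moves the read-out much further. The first step is a bound rather than a size, since it starts from a limit: the limit of > 25000 nM in this assay, at which 2 of the 4 values shown sit.

The compounds shown leave open whether the gain needs the ring nitrogen of pyridin-4-yl or only an aromatic ring, which phenyl on this carbon would separate. From the compounds shown here alone, how an amine or a longer chain would read out here also stays open.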